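Removing the second coumarin methyl: hydroxymethylbenzyl piperidine series

The source may report more compounds than this note shows. Statements on the series, on what has been measured and on what is new or still open speak of the compounds shown alone.

Compound 1 `Cc1c(C)c2ccc(OCC3CCN(Cc4ccc(CO)cc4)CC3)cc2oc1=O`: 1400 nM
Compound 2 `Cc1c(C)c2ccc(OCC3CCN(Cc4cccc(CO)c4)CC3)cc2oc1=O`: 1900 nM
Compound 3 `Cc1cc(=O)oc2cc(OCC3CCN(Cc4cccc(CO)c4)CC3)ccc12`: 3500 nM

In an assay for inhibition of Amine oxidase [flavin-containing] A (Homo sapiens), read by fluorescence, using microsomes, with a stated time of 30 min (on this read-out lower numbers stand for stronger inhibition and higher numbers for weaker inhibition), compound 2 gives 1900 nM, which stands second highest of the three numbers, with compound 1 nearest and compound 3 furthest, both within the scatter. Compound 4 `Cc1cc2ccc(OCC3CCN(Cc4cccc(CO)c4)CC3)cc2oc1=O` differs from compound 2 by hydrogen in place of methyl on an aromatic carbon. Among the compounds with values here, the one measured step that bears on this change is a 1.8-fold higher number from compound 2 to compound 3 (0.27 log units; within the scatter), where the methyl is lost from the other aromatic carbon of the same ring; the step of a 1.4-fold higher number from compound 1 to compound 2 (0.13 log units; within the scatter) concerns the hydroxymethyl position and does not bear on it. A change of the same kind on the same ring gave a step within the scatter, so for compound 4 a step no larger than that, if any, is expected, tending toward a higher number: a 1.5-fold higher number from compound 2 to compound 4 (0.17 log units; within the scatter). Compound 4 is therefore estimated at 2800 nM, with a range from 1200 nM to 6500 nM.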

Compound 4, half-maximal inhibitory concentration: 3900 nM
The estimate for compound 4 lay 1.4-fold (0.14 log units) below the measured number, and the stated range covers the measured number.
By their numbers in this assay, from the lowest: compounds 1, 2, 3 and 4 (each within the scatter of the next, the first and the last beyond it).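

In this assay, within the data shown here, hydrogen in place of methyl on the aromatic carbon opposite the ring oxygen gives a 2.1-fold higher number from compound 2 to compound 4 (0.31 log units; beyond the scatter), the first single change to lie beyond the scatter, though only modestly. Among these compounds, the earlier loss of a methyl from the same ring, a 1.8-fold higher number from compound 2 to compound 3 (0.27 log units; within the scatter), stayed within the scatter, so this methyl is the only one of the two whose removal gives a step beyond the scatter, and the earlier compounds did not show this. No available evidence accounts for the step.

The compounds shown leave open how an ethyl group, a longer chain or a chlorine atom on this carbon would compare with methyl. They also leave open whether the same step would appear with the 4-(hydroxymethyl)phenyl group of compound 1, or when both methyl groups are replaced by hydrogen.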